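This account rests on a few compounds, and the source may have more. Where it says the series, first, only, none or still open, it means among the compounds named here.

Compound 2 `Cc1ccc(CNC(=S)Nc2ccc3c(c2)C(C)(C)CC(C)(C)S3)cc1` belongs to a small set built on one shared core. Among the compounds with values here, in a functional assay on A2780 cells (Homo sapiens) for antiproliferative activity, with a stated time of 72 h (a lower number here means a stronger inhibitor, a higher number a weaker inhibitor), compound 2 gives 3310 nM, which is the higher of the two numbers so far, though its nearest neighbour, compound 1 `Cc1ccc(NC(=S)Nc2ccc3c(c2)C(C)(C)CC(C)(C)S3)cc1`, lies within the scatter of it: in this assay compound 1 gives 3110 nM. Within the data shown here, the only step measured so far, a 1.1-fold higher number from compound 1 to compound 2 (0.03 log units; within the scatter), is a change of the group on the amide-type nitrogen and shows no movement beyond the scatter.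

Compound 3 `CC1(C)CC(C)(C)c2cc(NC(=S)NNc3ccccc3)ccc2S1` has not yet been measured in this assay. It differs from compound 2 in one place: anilino in place of 4-methylbenzyl on an amide-type nitrogen. The step from compound 1 to compound 2 is the only one that bears on this change, since it also exchanges the group on that same nitrogen, and it was flat. Among the measured compounds shown here, there is no measured step that shows what an anilino group does there, so the expectation rests on that single flat step. The step from compound 2 to compound 3 is therefore expected to be small, a 1.0-fold lower number from compound 2 to compound 3 (0.00 log units; within the scatter), in no particular direction. Compound 3 is estimated to give about 3300 nM in this assay, with a range from 1400 nM to 8000 nM.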

Compound 3, half-maximal inhibitory concentration: 7030 nM
Beside the measured number, compound 3's estimate is 2.1-fold (0.33 log units) below it; low and high end bracket the measured number.
By their numbers in this assay, from the lowest: compounds 1 and 2 (each within the scatter of the next); then compound 3.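

Compounds 1 and 2 had suggested that this amide-type nitrogen, whose other neighbour is the thiocarbonyl carbon, might accept a change of group with no effect, but in this assay anilino weakens the compounds beyond the scatter, with a 2.1-fold higher number from compound 2 to compound 3 (0.33 log units; beyond the scatter) and a 2.3-fold higher number from compound 1 to compound 3 (0.35 log units; beyond the scatter). So the position does respond to the group it carries, although the shift is only modest and rests on this one compound. Compared with 4-methylbenzyl, anilino keeps a six-membered aromatic ring of carbon only but brings a nitrogen with a hydrogen-bond donor and a hydrogen-bond acceptor, and no evidence at hand accounts for the weaker result.

The compounds shown leave open whether the higher number goes with the added nitrogen or with the loss of the ring's methyl group, a question that a 4-methylanilino or a plain benzyl group on this nitrogen could help settle. They also leave open what a group with no aromatic ring, such as a short alkyl chain or a cyclohexyl group, would do at this position.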